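The source may report more compounds than this note shows. Statements on the series, on what has been measured and on what is new or still open speak of the compounds shown alone.

Working notes on the series. Compound 1 `COc1ccc(NC(=O)c2ccc(-c3cnc(N4CCCN(C)CC4)nc3)cc2O)cc1Cl` and compound 2 `CN1CCN(c2ncc(-c3ccc4c(NC5CCCCC5)ccnc4c3)cn2)CC1` share the same core, and compound 3 `CN1CCN(c2ncc(-c3ccc4c(N[C@@H]5CCCC[C@H]5O)ccnc4c3)cn2)CC1` is the analogue of compound 2 that has not yet been tested. In an ADME assay on HepG2 cells (Homo sapiens) for cytotoxicity, read by MTT assay, with a stated time of 48 h (a lower number here means that less compound is tolerated, a higher number that more compound is tolerated), compound 1 gives > 6.5 uM, which is a limit of the assay and not a number. This is the limit of > 6.5 uM in this assay, at which 1 of the 2 values shown sits. For compound 2 the result in this assay is "not determined" (no result reported), so compound 2 stands nowhere on the scale. For the measured compounds named here, the only value shown for the series is the limit of compound 1, and no step between measured compounds exists. The change from compound 2 to compound 3 is hydroxy in place of hydrogen on a saturated ring carbon. Going by the values given here, with no measured step in the set, the size of the step from compound 2 to compound 3 in this assay cannot be read from data; the expectation is for no shift beyond the usual scatter, in either direction. Compound 3 is therefore estimated at 8 uM in this assay, within a range from 3 uM to 30 uM, with a strong chance that only a limit is reported.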

Compound 3, half-maximal toxic concentration: > 3.6 uM
Compound 3 ended at the assay's limit; the forecaster's own chance of this, stated with the estimate: 70%; the middle value does not contradict the limit.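

In this assay compound 3 gives > 3.6 uM, which is a limit of the assay and not a number. For the compounds shown here, compound 2 has no number on this scale, so no step from compound 2 to compound 3 can be read. The compounds shown leave open whether cyclohexylamino to (2-hydroxycyclohexyl)amino shifts the tolerated concentration at all.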